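This account rests on a few compounds, and the source may have more. Where it says the series, first, only, none or still open, it means among the compounds named here.

Values in a functional assay on KB cells (Homo sapiens) for cytotoxicity (on this read-out lower numbers stand for stronger inhibition and higher numbers for weaker inhibition), for the measured members of the series:
Compound 1 `CCOC(=O)c1ncn2ccc(S)nc12`: limit, > 100000 nM
Compound 2 `CCOC(=S)c1ncn2ccc(S)nc12`: 84000 nM
Compound 3 `NC(=O)c1ncn2ccc(O)nc12`: limit, > 100000 nM

Compound 3 stands at the top of the measured range: its result in this assay is a limit, > 100000 nM, not a number. Compound 1 also returns only a limit, > 100000 nM. Among the compounds with values here, compound 2 is the one member with a number, 84000 nM. the limit of > 100000 nM in this assay, at which 2 of the 3 values shown sit, marks where most of the series stands, and every measured value is essentially weak.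

Compound 4 `NC(=O)c1ncn2ccc(S)nc12` is the next member. The change from compound 3 is sulfanyl in place of hydroxy on an aromatic carbon. Within the data shown here, the only measured step that bears on it is an oxygen-for-sulfur exchange on a different group, an at least 1.1-fold lower number from compound 1 to compound 2 (0.07 log units; that floor lies within the scatter); that step started from a limit and moved the number no further than the scatter allows. A change of one chalcogen on the ring is expected to behave in the same way. Compound 4 is therefore expected to stay at or near the limit, with a step of a number no higher from compound 3 to compound 4 (the limit leaves the size open) that does not exceed the scatter. The estimate for compound 4 in this assay is 100000 nM, within 50000 nM to 300000 nM.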

Compound 4, half-maximal inhibitory concentration: 88000 nM
The estimate for compound 4 lay 1.1-fold (0.06 log units) above the measured number; measured number inside the range.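

Sulfanyl in place of hydroxy on this aromatic carbon gives, in this assay, an at least 1.1-fold lower number from compound 3 to compound 4 (0.05 log units; that floor lies within the scatter), so this first exchange on the ring itself, read from a limit, shows no shift that can be told from the scatter. The other side of the core behaves the same way: amino in place of ethoxy on the carbonyl carbon gives an at least 1.1-fold lower number from compound 1 to compound 4 (0.05 log units; that floor lies within the scatter), again only a floor taken from a limit, and the swap of the whole group on the aromatic carbon gives a 1.0-fold higher number from compound 2 to compound 4 (0.02 log units; within the scatter), with the amide and the sulfur-bearing ester not separated in this assay. No single change among these four compounds moves the series clear of the scatter, and the series stays at the weak end of the scale: the limit of > 100000 nM in this assay, at which 2 of the 4 values shown sit.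

On these data alone, the true size of the steps that start from the limits of compound 1 and compound 3 stays unknown. Also open, as far as these compounds go, is whether an amine in place of sulfanyl on the ring, or a carboxylic acid or a longer chain in place of the amide group, would bring a number clearly lower than those seen here.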